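Swapping a Bromoethyl Chain for a Nitrofuran Ring

This account rests on a few compounds, and the source may have more. Where it says the series, first, only, none or still open, it means among the compounds named here.

Compound 1 `COc1ncc(-c2ccc3ncnc(N[C@H]4CCCN(C(=O)CCBr)C4)c3c2)cc1C#N` was measured in a functional assay on SU-DHL-6 cells (Homo sapiens) for antiproliferative activity, read by MTT assay (on this read-out higher numbers stand for weaker inhibition and lower numbers for stronger inhibition), where compound 1 gives 15 nM, the lowest of the two numbers recorded. Among the compounds with values here, its only measured neighbour, compound 2 `CCOC(=O)CN1CCC[C@H](Nc2ncnc3ccc(-c4cnc(OC)c(C#N)c4)cc23)C1`, gives 500 nM in this assay, and the step of a 33-fold higher number from compound 1 to compound 2 (1.52 log units; beyond the scatter) shows that replacing the (2-bromoethyl)carbonyl group cost a great deal of activity. Compound 3 `COc1ncc(-c2ccc3ncnc(N[C@H]4CCCN(C(=O)c5coc([N+](=O)[O-])c5)C4)c3c2)cc1C#N` is a new variant of compound 1: 5-nitrofuran-3-yl in place of 2-bromoethyl on a carbonyl carbon. Within the data shown here, in the one step measured so far the whole (2-bromoethyl)carbonyl group was replaced; in compound 3 the 2-bromoethyl part leaves while the carbonyl stays. Among the measured compounds shown here, because that step, a 33-fold higher number from compound 1 to compound 2 (1.52 log units; beyond the scatter), was large, a weakening of similar order is expected here too, though the entering group is different and the single comparison leaves the size uncertain. Compound 3 is therefore expected to give about 300 nM in this assay, between 60 nM and 1500 nM, corresponding to an estimated step of a 20-fold higher number from compound 1 to compound 3 (1.30 log units; beyond the scatter).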

Compound 3, half-maximal inhibitory concentration: 140 nM
Compound 3: the middle estimate sits 2.1-fold (0.33 log units) above what was measured; low and high end bracket the measured number.
By their numbers in this assay, from the lowest: compound 1; then compound 3; then compound 2.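

In this assay, the carbonyl on the amide-type nitrogen in a ring can stay in place and activity still falls when only the group on it changes, with a 9.3-fold higher number from compound 1 to compound 3 (0.97 log units; beyond the scatter). Even so, the (5-nitrofuran-3-yl)carbonyl group does better than (ethoxycarbonyl)methyl at the same nitrogen, with a 3.6-fold lower number from compound 2 to compound 3 (0.55 log units; beyond the scatter), so the two replacements of the (2-bromoethyl)carbonyl group differ in cost and a five-membered aromatic ring at this place still leaves compound 3 with clear activity. There is no measurement that explains either step.

On these data alone, it remains open whether the drop from compound 1 comes from losing the bromine or from bringing in the nitrofuran ring. A plain propanoyl group without bromine, or a furan ring without the nitro group, would help to separate these two possibilities.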